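A few compounds are considered here, and "the series" means these few. Any claim that something is new, unique, unknown or untested is made for them only; others in the source may bear on it.

Working notes on the series, with values from a functional assay on CNE-2 cells (Homo sapiens) for cytotoxicity, read by sulforhodamine B assay, with a stated time of 48 h (a higher number here means a weaker inhibitor, a lower number a stronger inhibitor), as follows:

- compound 1 `COc1ccc(/C=C/C(=O)c2cccc(-c3cccc(F)c3)c2)cc1O` gives "not determined" (no result reported)
- compound 2 `O=C(/C=C/c1cccc(Br)c1)c1cccc(-c2cccc(F)c2)c1` gives 6550 nM
- compound 3 `COc1ccc(-c2cc(C(=O)/C=C/c3cccc(OC)c3OC)ccc2N)cc1OC` gives 6600 nM

For the measured compounds named here, only two numbers are available so far. Compound 3 stands level with compound 2 at 6550 nM within the usual scatter of repeated measurements, and compound 1 offers no number for comparison. Going by the values given here, no two measured compounds differ in one place only, so the series gives no direct measure of what a single change does.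

Next in line is compound 4 `COc1ccc(/C=C/C(=O)c2ccc(N)c(-c3ccc(OC)c(OC)c3)c2)c(OC)c1` which has not yet been measured. Relative to compound 3, the change is 2,4-dimethoxyphenyl in place of 2,3-dimethoxyphenyl on a double-bonded chain carbon bound to a double-bonded chain carbon and the two compounds have the same atoms, joined differently. Among the compounds with values here, with no measured step to draw on, no direction can be favoured, and the estimate rests on compound 3 at 6600 nM as the closest measured neighbour. In this assay the expected change is a 1.1-fold lower number from compound 3 to compound 4 (0.04 log units; within the scatter) and it is expected to stay within the scatter. The estimated value for compound 4 is 6000 nM with an expected range from 2000 nM to 18000 nM given how little the series shows so far.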

Compound 4, half-maximal inhibitory concentration: 8340 nM
Compound 4: the middle estimate sits 1.4-fold (0.14 log units) below what was measured; measured number inside the range.
By their numbers in this assay, from the lowest: compounds 2, 3 and 4 (each within the scatter of the next).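

Placing 2,4-dimethoxyphenyl in place of 2,3-dimethoxyphenyl on a double-bonded chain carbon bound to a double-bonded chain carbon gives the first comparison in the series between compounds that differ in one place, and in this assay the step is within the scatter (a 1.3-fold higher number from compound 3 to compound 4 (0.10 log units; within the scatter)). With the same atoms joined differently, the two isomers stand level, so this pair gives no sign that the arrangement of the two methoxy groups on this ring matters in this assay, though it covers only this one rearrangement. No measured evidence bears on this result, so nothing can be said of what lies behind it.

Whether a carboxylic acid or a trifluoromethyl group on this ring would give a number beyond the scatter remains open, since the one step shown only exchanges one dimethoxyphenyl for another. The contribution of the amine and of the dimethoxyphenyl group on the other side of the carbonyl also remains open, as compound 3 and compound 4 share both and no pair shown differs there in one place only.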